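A Ring Swap on the Shared Core Toward Compound 4

The source may report more compounds than this note shows. Statements on the series, on what has been measured and on what is new or still open speak of the compounds shown alone.

Compound 1 `O=C(Nc1ccc(-n2ncc3c(Cl)cccc32)cc1)Nc1ccc(Cl)c(C(F)(F)F)c1`: 1600 nM
Compound 2 `Cc1cccc2c1cnn2-c1ccc(NC(=O)Nc2ccc(Cl)c(C(F)(F)F)c2)cc1`: 2300 nM
Compound 3 `O=C(Nc1ccc(-n2ncc3c(C(F)(F)F)cccc32)cc1)Nc1ccc(C(F)(F)F)cc1`: 2000 nM

All three were tested in a functional assay on MDA-MB-231 cells (Homo sapiens) for cytotoxicity, read by MTT assay, with a stated time of 72 h; a lower number here means a stronger inhibitor, a higher number a weaker inhibitor. Compound 1 gives the lowest of the three numbers, but compound 3 and compound 2 sit within the scatter of it, so no order among them can be claimed. Compound 4 `O=C(Nc1ccc(-n2ncc3ccncc32)cc1)Nc1ccc(Cl)c(C(F)(F)F)c1` has not yet been measured. It differs from compound 1 in one place: a group of 9 heavy atoms (6 carbon, 3 nitrogen; one five-membered aromatic ring with 2 hetero atoms, one six-membered aromatic ring with 1 hetero atom) in place of a group of 10 heavy atoms (7 carbon, 2 nitrogen, 1 chlorine; one five-membered aromatic ring with 2 hetero atoms, one six-membered aromatic ring of carbon only), on an aromatic carbon. Among the measured compounds shown here, the only measured single step, a 1.4-fold higher number from compound 1 to compound 2 (0.16 log units; within the scatter), altered the same part of the core and stayed within the scatter. For the measured compounds named here, no measured step replaces the 4-chloro-1H-indazol-1-yl group with a group whose six-membered ring carries a hetero atom, so the footing is thin. Compound 4 is therefore expected at 2000 nM, within 800 nM to 5000 nM. That estimate means an expected step of a 1.3-fold higher number from compound 1 to compound 4 (0.10 log units; within the scatter), nothing beyond the scatter.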

Compound 4, half-maximal inhibitory concentration: > 32000 nM
Compound 4: no number, only a limit; the forecaster's own chance of this, stated with the estimate: 5%; middle value at least 16-fold (1.20 log units) from the limit.
By their numbers in this assay, from the lowest: compounds 1, 3 and 2 (each within the scatter of the next). At a limit, above all of these: compound 4.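

In this assay, compound 4 gives no number, only a limit: > 32000 nM. The steps to it are large: an at least 20-fold higher number from compound 1 to compound 4 (1.30 log units; beyond the scatter), and an at least 13-fold higher number from compound 2 to compound 4 (1.14 log units; beyond the scatter). So this group on the shared core is not freely exchangeable, although methyl in place of chloro stayed within the scatter: a 1.4-fold higher number from compound 1 to compound 2 (0.16 log units; within the scatter).

The change to compound 4 removes the chloro or methyl group and also puts a nitrogen into the six-membered ring, and these compounds cannot separate the two. An amine on the carbon-only ring, in place of chloro, would leave that ring's atoms unchanged.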